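Swapping the amide substituent of compound 3 for pyridin-3-yl

The source may report more compounds than this note shows. Statements on the series, on what has been measured and on what is new or still open speak of the compounds shown alone.

Of the compounds shown here, three share one core and have been tested in a physicochemical assay for solubility, in phosphate buffer, measured as kinetic solubility, with a stated time of 1 h, at pH 7.4; a lower number here means a less soluble compound, a higher number a more soluble compound. Compound 1 `CSc1ccc2nc(C)cc(OCC(=O)Nc3cc(C)cc(C)c3)c2c1` gives 3000 nM in this assay. Compound 2 `CCCc1cc(OCC(=O)Nc2cc(C)cc(C)c2)c2cc(OC)ccc2n1` gives 12000 nM. Compound 3 `COc1ccc2nc(C)cc(OCC(=O)NCc3cc(C)cc(C)c3)c2c1` gives 92000 nM, the highest of the three numbers; its nearest neighbour is compound 2, whose value is lower by more than the scatter, and the gap to compound 1 is larger still.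

Compound 4 `COc1ccc2nc(C)cc(OCC(=O)Nc3cccnc3)c2c1` has not yet been measured. It differs from compound 3 in one place: pyridin-3-yl in place of 3,5-dimethylbenzyl on an amide-type nitrogen The amide nitrogen of compound 4 thus carries a ring directly, as in compound 1 and compound 2, rather than through the extra carbon of the benzyl group in compound 3.

Going by the values given here, no measured pair shows this change, so the expectation rests on the single replacement alone. The step from compound 3 to compound 4 in this assay is expected to be small, a 1.1-fold higher number from compound 3 to compound 4 (0.04 log units; within the scatter), and not clearly beyond the scatter in either direction. Compound 4 is therefore estimated to give 100000 nM in this assay, within a range from 30000 nM to 350000 nM.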

Compound 4, solubility: 32000 nM
Estimate against measurement, compound 4: 3.1-fold (0.49 log units) above, within the range that was stated.
By their numbers in this assay, from the lowest: compound 1; then compound 2; then compound 4; then compound 3.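

Going by these compounds alone, the change on the amide-type nitrogen gives a 2.9-fold lower number from compound 3 to compound 4 (0.46 log units; beyond the scatter) in this assay, so a modest step beyond the scatter is seen at this place for the first time. In this swap, 3,5-dimethylbenzyl, with 9 heavy atoms, all carbon, leaves and pyridin-3-yl, with 6 heavy atoms including 1 nitrogen, enters, and the number goes down. Nothing measured here explains why it does.

This single swap changes the ring, its two methyl groups and the carbon that joins the benzyl ring to the nitrogen all at once, and the compounds shown do not separate these parts. Where an unsubstituted phenyl or a pyridin-3-ylmethyl group on the same nitrogen would fall relative to compound 3 and compound 4 remains open.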